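Working notes: from compound 2 to compound 3

The source may report more compounds than this note shows. Statements on the series, on what has been measured and on what is new or still open speak of the compounds shown alone.

- compound 1 `Cc1ccc(/C=C/C(=O)NNC(=O)c2ccc3c(c2)OCCO3)cc1` gives 1050 nM
- compound 2 `O=C(/C=C/c1ccccc1[N+](=O)[O-])NNC(=O)c1ccc2c(c1)OCCO2` gives 890 nM

For the measured compounds named here, in a functional assay on cells (Cancer cell lines, Homo sapiens) for inhibition, read by MTT assay, with a stated time of 48 h (a lower number here means a stronger inhibitor, a higher number a weaker inhibitor), compound 2 gives 890 nM and stands within the scatter of compound 1, the only other measured compound. Compound 3 `COc1cccc(/C=C/C(=O)NNC(=O)c2ccc3c(c2)OCCO3)c1` is unmeasured, and 3-methoxyphenyl in place of 2-nitrophenyl on a double-bonded chain carbon bound to a double-bonded chain carbon is the whole change from compound 2, with 3-methoxyphenyl in place of 2-nitrophenyl. Going by the values given here, the one measured step at this place is a 1.2-fold lower number from compound 1 to compound 2 (0.07 log units; within the scatter) and it stays within the scatter. Among the compounds with values here, with only that step to go on, no change beyond the scatter is expected in this assay for this swap. The estimated step is a 1.1-fold higher number from compound 2 to compound 3 (0.03 log units; within the scatter) as a working figure. The estimate for compound 3 is 950 nM with 400 nM to 2300 nM as its expected range.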

Compound 3, half-maximal inhibitory concentration: 170 nM
Estimate against measurement, compound 3: 5.6-fold (0.75 log units) above; measured number outside the range, below it.
By their numbers in this assay, from the lowest: compound 3; then compounds 2 and 1 (each within the scatter of the next).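

In this assay 3-methoxyphenyl on a double-bonded chain carbon bound to a double-bonded chain carbon gives a 5.2-fold lower number from compound 2 to compound 3 (0.72 log units; beyond the scatter) and a 6.2-fold lower number from compound 1 to compound 3 (0.79 log units; beyond the scatter) and so sets itself apart from both earlier groups. The aryl group at this place can therefore move the number beyond the scatter, which the swap between 4-methylphenyl and 2-nitrophenyl did not show. Nothing available accounts for this difference. As far as these compounds go, whether 4-methoxyphenyl or 3-aminophenyl at this place would keep the lower number stays open.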